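This account rests on a few compounds, and the source may have more. Where it says the series, first, only, none or still open, it means among the compounds named here.

Among the measured compounds shown here, in an ADME assay on the whole organism (Rattus norvegicus, strain Sprague-Dawley) for pharmacokinetics, read by LC-MS, with a stated time of 72 h, at a dose of 3 mg/kg by the oral route (a higher number here means more compound in the circulation at the dose given, a lower number less compound in the circulation), compound 2 `CN1CC[C@H](N(c2cc(C#CC(C)(C)C)sc2C(=O)O)C(=O)[C@H]2CC[C@H](C)CC2)C1=O` gives 176 ng.h/mL, the lower of the two numbers so far, while compound 1 `CN1CC[C@@H](N(c2cc(C#CC(C)(C)C)sc2C(=O)O)C(=O)[C@H]2CC[C@H](C)CC2)C1=O` gives 3320 ng.h/mL. Compound 3 `CN1CCCC[C@@H](N(c2cc(C#CC(C)(C)C)sc2C(=O)O)C(=O)[C@H]2CC[C@H](C)CC2)C1=O` carries 1-methyl-2-oxoazepan-3-yl in place of 1-methyl-2-oxopyrrolidin-3-yl on an amide-type nitrogen. Its stereocentre in that ring is drawn in the same sense as in compound 1, not as in compound 2. For the measured compounds named here, only one measured step bears on this: a 19-fold lower number from compound 1 to compound 2 (1.28 log units; beyond the scatter), a large step that comes with the fact that compounds 1 and 2 differ only in the configuration as drawn. Going by the values given here, no measured step covers the seven-membered ring, so its contribution is unknown and the range must stay wide. Compound 3 is expected to recover much, but not all, of the gap seen in that step. The estimated change is a 6.8-fold higher number from compound 2 to compound 3 (0.83 log units; beyond the scatter). For compound 3 the expected value is 1200 ng.h/mL, with an estimated range of 250 ng.h/mL to 5000 ng.h/mL.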

Compound 3, area under the concentration-time curve: 3530 ng.h/mL
For compound 3 the middle estimate is 2.9-fold (0.47 log units) below the measured one; the range from low to high includes it.
By their numbers in this assay, from the lowest: compound 2; then compounds 1 and 3 (each within the scatter of the next).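

In this assay, with the stereocentre drawn in the same sense, 1-methyl-2-oxoazepan-3-yl in place of 1-methyl-2-oxopyrrolidin-3-yl on the amide-type nitrogen gives a 1.1-fold higher number from compound 1 to compound 3 (0.03 log units; within the scatter), so the two ring sizes cannot be told apart here. The change that also carries the opposite drawn sense gives a 20-fold higher number from compound 2 to compound 3 (1.30 log units; beyond the scatter). Only compound 2 stands apart, which suggests that at this position the drawn configuration counts for more than the ring size, a reading that rests on a single pair: the fact that compounds 1 and 2 differ only in the configuration as drawn

As far as these compounds go, whether the seven-membered ring drawn in the opposite sense would show a similar gap remains open. Also open, from the compounds shown here alone, are how a six-membered 1-methyl-2-oxopiperidin-3-yl group would behave and what an ethyl or longer chain on the ring nitrogen in place of methyl would do.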